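The compounds below may be only part of what the source reports. "The series", "measured", "known", "first", "only" and "open" are said of these compounds alone.

Measured in a functional assay on B16-F10 cells (Mus musculus) for inhibition, read by MTT assay, with a stated time of 72 h; on this read-out lower numbers stand for stronger inhibition and higher numbers for weaker inhibition:

Compound 1 `CC(C)c1ccc(-c2nc(SCc3cn(CC(=O)NC(=O)Nc4ccccn4)nn3)nc(Nc3cccc(C(F)(F)F)c3)c2C#N)cc1` gives 1700 nM.
Compound 2 `Cc1ccc(Nc2nc(SCc3cn(CC(=O)NC(=O)Nc4ccccn4)nn3)nc(-c3ccc(C(C)C)cc3)c2C#N)cc1` gives 3060 nM.
Compound 3 `COc1cc(-c2nc(SCc3cn(CC(=O)NC(=O)Nc4ccccn4)nn3)nc(Nc3ccc(C)cc3)c2C#N)cc(OC)c1OC` gives 32 nM.

Compound 3 stands lowest in this assay: compound 1 is beyond the scatter above it, and compound 2 further still. Compound 4 `COc1cc(-c2nc(SCc3cn(CC(=O)NC(=O)Nc4ccccn4)nn3)nc(Nc3cccc(C(F)(F)F)c3)c2C#N)cc(OC)c1OC` has not yet been measured. It differs from compound 3 in one place, (3-(trifluoromethyl)phenyl in place of 4-methylphenyl on a nitrogen on an aromatic ring). The same change appears once more among these compounds, from compound 2 to compound 1, where it gave a 1.8-fold lower number from compound 2 to compound 1 (0.26 log units; within the scatter). The two cores on which the change is made are not identical: compound 3 differs from compound 2 by 3,4,5-trimethoxyphenyl in place of 4-isopropylphenyl on an aromatic carbon, and that change gave a 96-fold lower number from compound 2 to compound 3 (1.98 log units; beyond the scatter). The surroundings of the exchanged group are described in the same words for both pairs, so the change is the same one in both. The step from compound 3 to compound 4 is expected to be about a 1.6-fold lower number from compound 3 to compound 4 (0.20 log units; within the scatter), resting on the within-scatter step a 1.8-fold lower number from compound 2 to compound 1 (0.26 log units; within the scatter) that the same change gave before. Compound 4 is therefore estimated at 20 nM, with a likely range from 6 nM to 70 nM.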

Compound 4, half-maximal inhibitory concentration: 24400 nM
Estimate against measurement, compound 4: 1200-fold (3.09 log units) below; measured number above the stated range.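

In this assay, the exchange of 4-methylphenyl for 3-(trifluoromethyl)phenyl did not carry over from one core to the other: on the core bearing 3,4,5-trimethoxyphenyl it gave a 760-fold higher number from compound 3 to compound 4 (2.88 log units; beyond the scatter), and the two results for this change disagree: the same change on two cores in this assay, a 1.8-fold lower number (0.26 log units; within the scatter) from compound 2 to compound 1 and a 760-fold higher number (2.88 log units; beyond the scatter) from compound 3 to compound 4, 1400-fold (3.14 log units) apart, beyond the scatter of two such steps

Seen from the other side, the exchange of 4-isopropylphenyl for 3,4,5-trimethoxyphenyl also depends on the group on the nitrogen, giving a 14-fold higher number from compound 1 to compound 4 (1.16 log units; beyond the scatter) when that group is 3-(trifluoromethyl)phenyl, and here too the two results disagree: the same change on two cores in this assay, a 96-fold lower number (1.98 log units; beyond the scatter) from compound 2 to compound 3 and a 14-fold higher number (1.16 log units; beyond the scatter) from compound 1 to compound 4, 1400-fold (3.14 log units) apart, beyond the scatter of two such steps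

So in these four compounds the two changes do not act independently and a step measured on one core is a poor guide to the other, but the data do not show why, or whether this holds beyond this one pair of groups.

As far as these compounds go, how an unsubstituted phenyl or a chlorophenyl group on that nitrogen would behave on each core stays open. So does whether a methoxyphenyl group in place of 3,4,5-trimethoxyphenyl would show the same dependence.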